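Moving a hydroxyl on a pyridine-linked phenyl ring

The compounds below may be only part of what the source reports. "The series", "measured", "known", "first", "only" and "open" are said of these compounds alone.

Compound 1 `Oc1ccc(-c2cc(-c3cccs3)cc(-c3cccc(O)c3)n2)cc1` gives 1.1% in an assay on isolated protein for inhibition of DNA topoisomerase 1 (Homo sapiens), with a stated time of 30 min, tested at 20 uM; on this read-out lower numbers stand for a weaker effect and higher numbers for a stronger effect at the one concentration tested. Compound 2 `Oc1cccc(-c2cc(-c3ccoc3)cc(-c3ccccc3O)n2)c1` stands at "not determined" (no result reported) in this assay, as no result was reported for it. Compound 3 `Oc1ccc(-c2cc(-c3ccoc3)cc(-c3cccc(O)c3)n2)cc1` differs from compound 2 by 4-hydroxyphenyl in place of 2-hydroxyphenyl on an aromatic carbon. Among the compounds with values here, with no measured step on record between compound 2 and compound 3, and compound 2 itself unmeasured, the author expects the change to fall within the usual scatter of this assay, in no firm direction. Given that compound 1 shows 1.1%, compound 3 is estimated at 3% in this assay, with a range from 0% to 15%.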

Compound 3, a percentage reported as inhibition, at one concentration (the size of the read-out at that concentration, not a potency): 1.3%
Beside the measured number, compound 3's estimate is 1.7 percentage points above it, within the range that was stated.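

In this assay the result gives a first readable step, a number 0.2 percentage points higher from compound 1 to compound 3 (within the scatter), for furan-3-yl in place of thiophen-2-yl on an aromatic carbon, so this exchange does not separate the two compounds. The step from 2-hydroxyphenyl to 4-hydroxyphenyl cannot be read, as compound 2 has no number. No evidence on hand bears on this result.

The compounds shown leave open how 2-hydroxyphenyl compares with 4-hydroxyphenyl at this position. They also leave open whether an amine or a carboxylic acid in place of the hydroxyl would change the read-out.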